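Pyrrolidine in place of pyrrole on the core's methylene

The source may report more compounds than this note shows. Statements on the series, on what has been measured and on what is new or still open speak of the compounds shown alone.

Compound 1 `Cc1nc2cc(-c3c[nH]nc3C)sc2c(=O)[nH]1` gives 1500 nM in an assay for inhibition of Rho-associated protein kinase 1 (Homo sapiens), read by TR-FRET, with stated times of 5 min and 2 h; a lower number here means a stronger inhibitor, a higher number a weaker inhibitor. Going by the values given here, compound 2 `Cc1n[nH]cc1-c1cc2nc(Cn3cccc3)[nH]c(=O)c2s1` gives 370 nM in this assay; this is the lowest of the two numbers so far, with compound 1 the nearest at a higher number, and the step of a 4.1-fold lower number from compound 1 to compound 2 (0.61 log units; beyond the scatter) shows that the 1H-pyrrol-1-yl group on the saturated chain carbon bound to an aromatic carbon is what separates them. Compound 3 `Cc1n[nH]cc1-c1cc2nc(CN3CC[C@@H](C)C3)[nH]c(=O)c2s1` keeps that attachment point but carries a different ring: a group of 6 heavy atoms (5 carbon, 1 nitrogen; one five-membered non-aromatic ring with 1 hetero atom) in place of a group of 5 heavy atoms (4 carbon, 1 nitrogen; one five-membered aromatic ring with 1 hetero atom), on a saturated chain carbon bound to an aromatic carbon. Among the compounds with values here, only the step of a 4.1-fold lower number from compound 1 to compound 2 (0.61 log units; beyond the scatter) bears on this change, and it describes the gain from hydrogen to a ring, not a swap between two rings of similar size, so it sets no clear direction. For compound 3 a small move is expected in this assay, a 1.9-fold lower number from compound 2 to compound 3 (0.27 log units; within the scatter). Compound 3 is therefore estimated at 200 nM, within 60 nM to 700 nM.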

Compound 3, half-maximal inhibitory concentration: 540 nM
For compound 3 the middle estimate is 2.7-fold (0.43 log units) below the measured one; the measured number falls inside the stated range.
By their numbers in this assay, from the lowest: compounds 2 and 3 (each within the scatter of the next); then compound 1.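

In this assay the step of a 1.5-fold higher number from compound 2 to compound 3 (0.16 log units; within the scatter) shows that, on a saturated chain carbon bound to an aromatic carbon, the five-membered non-aromatic ring and the five-membered aromatic 1H-pyrrol-1-yl cannot be told apart, so an aromatic ring is not required here in these two compounds. The gain over hydrogen also holds for this second ring, as a 2.8-fold lower number from compound 1 to compound 3 (0.44 log units; beyond the scatter) shows, and both ring-bearing compounds therefore stand beyond the scatter from compound 1. No measurement at hand accounts for the two rings reading alike.

Still open, as far as these compounds go, is whether a ring is needed at all on this carbon, which an open-chain dimethylamino group would test, and whether a six-membered morpholine ring behaves like the five-membered rings. The shown compounds also leave open what the defined stereocentre contributes, since the mirror-image ring is not among them.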